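Swapping Hydroxy for Amino on a Second Core

The source may hold more compounds than are shown below. What is called first, only, known or untested is meant among the compounds shown, and "the series" means these compounds.

Compound 1 `COc1ccc(C(=O)c2ccc(OC)c3c2OC(C)(C)C=C3)c(NC(=O)CO)c1` and compound 2 `COc1ccc(C(=O)c2ccc(OC)c3c2OC(C)(C)C=C3)c(NC(=O)CN)c1` share one core, while compound 3 `C=C(c1ccc(OC)cc1NC(=O)CO)c1ccc(OC)c2c1OC(C)(C)C=C2` and the as yet unmeasured compound 4 `C=C(c1ccc(OC)cc1NC(=O)CN)c1ccc(OC)c2c1OC(C)(C)C=C2` share another; the difference between the two cores is not broken down here. In a functional assay on A2780 cells (Homo sapiens) for antiproliferative activity, read by MTT assay, with a stated time of 48 h (on this read-out higher numbers stand for weaker inhibition and lower numbers for stronger inhibition), compound 1 gives 100 nM and compound 2 gives 380 nM, so the change amino in place of hydroxy on a saturated chain carbon bound to a carbonyl carbon brought a 3.8-fold higher number from compound 1 to compound 2 (0.58 log units; beyond the scatter). In this assay compound 3 gives 40 nM. Compound 4 carries the same change, (amino in place of hydroxy on a saturated chain carbon bound to a carbonyl carbon), at the same place. Going by the values given here, the expectation for compound 4 is a step of a 3.8-fold higher number from compound 3 to compound 4 (0.57 log units; beyond the scatter), resting on the single earlier example because that change gave a 3.8-fold higher number from compound 1 to compound 2 (0.58 log units; beyond the scatter). Compound 4 is therefore estimated at about 150 nM, expected to fall between 70 nM and 350 nM.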

Compound 4, half-maximal inhibitory concentration: 80 nM
Compound 4: the middle estimate sits 1.9-fold (0.27 log units) above what was measured; the measured number falls inside the stated range.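

In this assay, amino in place of hydroxy on the second core gives a 2.0-fold higher number from compound 3 to compound 4 (0.30 log units; within the scatter). Set beside the step on the first core, the two steps cannot be told apart: the same change on two cores in this assay, a 3.8-fold higher number (0.58 log units; beyond the scatter) from compound 1 to compound 2 and a 2.0-fold higher number (0.30 log units; within the scatter) from compound 3 to compound 4, 1.9-fold (0.28 log units) apart, within the scatter of two such steps This suggests that the change carries from one core to the other without a clear difference in size, but it rests on a single pair per core, and the step on the second core alone is too small to count as a real change. It does not show that the change would behave alike on any other core, or why it acts as it does.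

The compounds shown leave open how a dimethylamino group, a carboxylic acid or a longer chain would fare in place of the hydroxy or amino.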